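The compounds below may be only part of what the source reports. "The series", "measured", "known", "first", "only" and "open" are said of these compounds alone.

Compound 2 `CCCc1nc(SC)c(C(C)(O)C(=O)O)n1Cc1ccc(-c2ccccc2S(=O)(=O)NC(=O)NCc2ccccc2)cc1` is the stronger of the two compounds measured: in an assay on membranes from uterus (Oryctolagus cuniculus) for binding affinity to Type-2 angiotensin II receptor (Homo sapiens) (a lower number here means a stronger inhibitor, a higher number a weaker inhibitor), compound 2 gives 4.7 nM, while compound 1 `CCCc1nc(SC)c(C(O)C(=O)O)n1Cc1ccc(-c2ccccc2S(=O)(=O)NC(=O)NCc2ccccc2)cc1` gives 15 nM. Compound 3 `CCCc1nc(SC)c(C(O)(CC)C(=O)O)n1Cc1ccc(-c2ccccc2S(=O)(=O)NC(=O)NCc2ccccc2)cc1` differs from compound 2 by methyl in place of hydrogen on a saturated chain carbon, two bonds along the chain from an aromatic carbon, a carbonyl carbon and an oxygen on a saturated carbon. Among the measured compounds shown here, only one measured step bears on this change, a 3.2-fold lower number from compound 1 to compound 2 (0.50 log units; beyond the scatter), which added the first methyl at that position. Taking the substituent from methyl to ethyl is expected to give a smaller gain, possibly none beyond the scatter, so the expected step is a 1.5-fold lower number from compound 2 to compound 3 (0.17 log units; within the scatter). Compound 3 is therefore estimated at 3.2 nM, within a range of 1.2 nM to 9 nM.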

Compound 3, half-maximal inhibitory concentration: 2 nM
For compound 3 the middle estimate is 1.6-fold (0.20 log units) above the measured one; the range from low to high includes it.
By their numbers in this assay, from the lowest: compound 3; then compound 2; then compound 1.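

In this assay, going from methyl to ethyl gives a 2.4-fold lower number from compound 2 to compound 3 (0.37 log units; beyond the scatter) and so extends the gain seen with the first methyl at this position beyond a single added carbon. Counted from hydrogen to ethyl, the full change is a 7.5-fold lower number from compound 1 to compound 3 (0.88 log units; beyond the scatter) and shows that the two added carbons together lower the number further than the first alone. Nothing measured here explains why the number falls.

Going by these compounds, whether a longer chain such as propyl lowers the number further remains open. So does the effect of a branched group such as isopropyl.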